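Replacing the Tert-Butyl Benzamide: Expectations for Compound 3

The compounds below may be only part of what the source reports. "The series", "measured", "known", "first", "only" and "open" are said of these compounds alone.

Compound 1 `COc1cc2ncnc(Nc3ccc(NC(=O)c4ccc(C(C)(C)C)cc4)cc3)c2cc1OC` gives in a functional assay on MCF7 cells (Homo sapiens) for inhibition, read by MTT assay (on this read-out lower numbers stand for stronger inhibition and higher numbers for weaker inhibition), only a limit, > 100000 nM. Compound 2 `COc1cc2ncnc(Nc3ccc(NC(=O)c4ccc(C(F)(F)F)cc4)cc3)c2cc1OC` likewise reaches only a limit in this assay, > 100000 nM. Within the data shown here, the single change between them, a step that the two limits leave unreadable from compound 1 to compound 2, therefore cannot be sized. Compound 3 `COc1cc2ncnc(Nc3ccc(NC(=O)c4cc(F)ccc4Br)cc3)c2cc1OC` differs from compound 1 by 2-bromo-5-fluorophenyl in place of 4-(tert-butyl)phenyl on a carbonyl carbon. Among the measured compounds shown here, no measured step bears on this change, and the only evidence, (the limit of > 100000 nM in this assay, at which 2 of the 2 values shown sit), supports no step beyond the scatter in this assay in either direction. Compound 3 is therefore expected to give 100000 nM in this assay, within 20000 nM to 500000 nM. This estimate corresponds to an expected step of a number no higher from compound 1 to compound 3 (the limit leaves the size open).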

Compound 3, half-maximal inhibitory concentration: 26000 nM
The estimate for compound 3 lay 3.8-fold (0.59 log units) above the measured number; the range from low to high includes it.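

In this assay, among these compounds, compound 3 is the first compound here to give a measured number rather than a limit, which shows that changing the group on the carbonyl carbon can move the read-out. Placing 2-bromo-5-fluorophenyl there in place of 4-(tert-butyl)phenyl gives an at least 3.8-fold lower number from compound 1 to compound 3 (0.58 log units; beyond the scatter), and placing it there in place of 4-(trifluoromethyl)phenyl gives an at least 3.8-fold lower number from compound 2 to compound 3 (0.58 log units; beyond the scatter). Both sizes are minimums, and the step between the two earlier compounds cannot be read.

The compounds shown do not tell whether the bromine, the fluorine or both together account for the change. Going by these compounds, how an amine or a carboxylic acid on this ring would behave also stays open.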